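A few compounds are considered here, and "the series" means these few. Any claim that something is new, unique, unknown or untested is made for them only; others in the source may bear on it.

Measured in an ADME assay on MT4 cells (Homo sapiens) for cytotoxicity, read by MTT assay, with a stated time of 96 h (a higher number here means that more compound is tolerated, a lower number that less compound is tolerated), each entry a limit:
- compound 1 `FC(F)(F)c1ccc(-c2nn(-c3ccccc3)cc2CNc2ccc(Cl)cc2)cc1` gives > 100000 nM as a limit
- compound 2 `Clc1ccc(NCc2cn(-c3ccccc3)nc2-c2ccc(Cl)cc2)cc1` gives > 100000 nM as a limit
- compound 3 `Cc1ccc(-c2nn(-c3ccccc3)cc2CNc2ccc(Cl)cc2)cc1` gives > 100000 nM as a limit

Compound 1 stands at > 100000 nM and this is a limit, not a number. The three compounds share the limit of > 100000 nM in this assay, at which 3 of the 3 values shown sit, and no order among them can be read.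

Compound 4 `FC(F)(F)c1ccc(-c2nn(-c3ccccc3)cc2CNc2ccc(Br)cc2)cc1` differs from compound 1 at the (4-chlorophenyl)amino group, which becomes (4-bromophenyl)amino: bromo in place of chloro on an aromatic carbon on an aromatic carbon, para to a large group.

The measured steps nearest to this change are a step that the two limits leave unreadable from compound 1 to compound 2 and a step that the two limits leave unreadable from compound 1 to compound 3 as well as a step that the two limits leave unreadable from compound 2 to compound 3 and none of them gives a size. None of them alters the (4-chlorophenyl)amino group either.

The expectation in this assay is therefore no step beyond the scatter, in neither direction, and it rests on compound 1 at > 100000 nM as a limit. The step expected is a number no higher from compound 1 to compound 4 (the limit leaves the size open) and this is only an estimate.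

Compound 4 is estimated at 100000 nM with an expected range from 50000 nM to 200000 nM and a report as a limit is the likeliest outcome.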

Compound 4, half-maximal cytotoxic concentration: > 100000 nM
Compound 4: a limit, no number (the forecaster's own chance of this, stated with the estimate: 85%); the middle value sits exactly at the limit.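

In this assay compound 4 gives > 100000 nM, a limit and not a number, so the step from compound 1 to compound 4 cannot be read: the limit of > 100000 nM in this assay, at which 4 of the 4 values shown sit.

The compounds shown leave open whether bromo and chloro differ here, and how far any of the four compounds lies from that limit.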